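The compounds below may be only part of what the source reports. "The series", "measured", "known", "first", "only" and "open" are said of these compounds alone.

Going by the values given here, compound 1 `COc1cc(F)c(NC(=O)c2ccncc2OC)cc1Nc1nccc(-c2cn(C)c3ccccc23)n1` is, on the numbers so far, the compound with the lowest value: in a functional assay on NCI-H1975 cells (Homo sapiens) for antiproliferative activity, read by MTT assay, with a stated time of 72 h (on this read-out higher numbers stand for weaker inhibition and lower numbers for stronger inhibition), compound 1 gives 4120 nM. Among the compounds with values here, its nearest neighbour is compound 2 `COc1cc(F)c(NC(=O)c2ncccn2)cc1Nc1nccc(-c2cn(C)c3ccccc23)n1`, which in this assay gives 13500 nM; the only measured step, a 3.3-fold higher number from compound 1 to compound 2 (0.52 log units; beyond the scatter), swaps the ring attached to the carbonyl carbon of the amide. Compound 3 `COc1cc(N(C)C)c(NC(=O)c2ccncc2OC)cc1Nc1nccc(-c2cn(C)c3ccccc23)n1` differs from compound 1 in a different part of the molecule: dimethylamino in place of fluoro on an aromatic carbon. Within the data shown here, neither measured compound varies at that aromatic carbon, so the measured step gives no direct guidance on how this position tolerates change; it shows only that a single group swap elsewhere can move the number by a modest amount. With no data at this position, the expectation for compound 3 is a step of about a 1.2-fold lower number from compound 1 to compound 3 (0.07 log units; within the scatter), that is, within the scatter. Compound 3 is therefore estimated to give around 3500 nM in this assay, expected to fall between 900 nM and 14000 nM.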

Compound 3, half-maximal inhibitory concentration: 12100 nM
Compound 3: middle estimate off by 3.5-fold (0.54 log units), on the low side; low and high end bracket the measured number.
By their numbers in this assay, from the lowest: compound 1; then compounds 3 and 2 (each within the scatter of the next).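

In this assay, the aromatic carbon that carries fluoro in compound 1 now has its first reading, and it is not indifferent to change: dimethylamino there gives a 2.9-fold higher number from compound 1 to compound 3 (0.47 log units; beyond the scatter) on an otherwise unchanged molecule. The swap replaces a single fluorine atom with a group of 3 heavy atoms that brings one hydrogen-bond acceptor, and of this pair the fluoro compound is the stronger inhibitor, so this position can move the number beyond the usual scatter. Nothing measured here accounts for the rise, so the pair records the change without explaining it.

On these data alone, with only one replacement at this carbon, it stays open whether the rise goes with the larger size of the group, with its nitrogen, or simply with the loss of fluoro. As far as these compounds go, a plain amino group, a methyl group or a chlorine atom on the same carbon would help to separate these readings, and it is also open whether dimethylamino would shift the number in the same way on the pyrimidin-2-yl amide of compound 2.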